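A few compounds are considered here, and "the series" means these few. Any claim that something is new, unique, unknown or untested is made for them only; others in the source may bear on it.

Compound 1 `NC1=NC2(CCOCC2)N(OCCCOc2ccc(Cl)c(Cl)c2)C(N)=N1` gives 1240 nM in a functional assay on HL-60 cells (Homo sapiens) for antiproliferative activity, read by MTT assay, with a stated time of 72 h; a higher number here means a weaker inhibitor, a lower number a stronger inhibitor.
Compound 2 `NC1=NC2(CCOCC2)N(OCCCOc2ccc(F)cc2)C(N)=N1` gives 2380 nM in this assay.
Compound 3 `NC1=NC2(CCOCC2)N(OCCCOc2ccc(Cl)cc2)C(N)=N1` gives 330 nM in this assay.

Compound 3 has the lowest number of the three, with a 3.8-fold lower number from compound 1 to compound 3 (0.57 log units; beyond the scatter) and a 7.2-fold lower number from compound 2 to compound 3 (0.86 log units; beyond the scatter) both beyond the scatter. Compound 4 `CC(C)(C)c1ccc(OCCCON2C(N)=NC(N)=NC23CCOCC3)cc1` differs from compound 3 by tert-butyl in place of chloro on an aromatic carbon. Among the measured compounds shown here, no measured step swaps chloro for tert-butyl; the steps that bear on it only show that removing one chloro, a 3.8-fold lower number from compound 1 to compound 3 (0.57 log units; beyond the scatter), and exchanging fluoro for chloro, a 7.2-fold lower number from compound 2 to compound 3 (0.86 log units; beyond the scatter), each moved the number modestly. For the measured compounds named here, with no close precedent, the expectation for compound 4 in this assay is a step of a 1.5-fold higher number from compound 3 to compound 4 (0.18 log units; within the scatter), likely within the scatter. Compound 4 is estimated at 500 nM, in the range 150 nM to 2000 nM.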

Compound 4, half-maximal inhibitory concentration: 870 nM
Compound 4: middle estimate off by 1.7-fold (0.24 log units), on the low side; measured number inside the range.
By their numbers in this assay, from the lowest: compound 3; then compounds 4, 1 and 2 (each within the scatter of the next, the first and the last beyond it).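

At this ring position in this assay, tert-butyl (4 heavy atoms) replaces chloro (1 heavy atom) with a 2.6-fold higher number from compound 3 to compound 4 (0.42 log units; beyond the scatter), yet it also gives a 2.7-fold lower number from compound 2 to compound 4 (0.44 log units; beyond the scatter) when it replaces fluoro. Tert-butyl therefore falls between the two halogens, so the number does not simply follow the heavy-atom count of the group. Nothing available explains this ordering. Still open, on these data alone, is how this assay would respond to an amine or a carboxylic acid at this position. A methoxy group there would also test whether an oxygen-linked group fits this ordering.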